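This account rests on a few compounds, and the source may have more. Where it says the series, first, only, none or still open, it means among the compounds named here.

Working notes on the series. In a toxicity assay on HepG2 2.2.15 cells (Homo sapiens) for cytotoxicity, read by CellTiter-Glo (a higher number here means that more compound is tolerated, a lower number that less compound is tolerated), compound 1 `N#CC1CC(=O)N(c2cnn3c2CN(C(=O)Nc2cc(F)c(F)c(F)c2)C(C2CC2)C3)C1` gives > 200000 nM, which is a limit of the assay and not a number. Compound 1 thus stands among the shown values only as a limit, and one further value shown is also a limit. Compound 2 `CC1(C)CC(=O)N(c2cnn3c2CN(C(=O)Nc2cc(F)c(F)c(F)c2)C(C2CC2)C3)C1` gives 115000 nM in this assay. Compound 3 `C[C@H]1Cn2ncc(N3CC(c4ccccc4)CC3=O)c2CN1C(=O)NCc1cc(F)c(F)c(F)c1` gives > 2000 nM in this assay, again a limit of the assay. Compound 3 differs from compound 1 in more than one place, so only its two values can be set side by side, and both are limits.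

Compound 4 `O=C1CC(c2ncco2)CN1c1cnn2c1CN(C(=O)Nc1cc(F)c(F)c(F)c1)C(C1CC1)C2` is to be measured in this assay. It differs from compound 1 by 1,3-oxazol-2-yl in place of cyano on a saturated ring carbon. For the measured compounds named here, the only measured step that bears on this change, an exchange at the same saturated ring carbon of the shared core, is an at least 1.7-fold lower number from compound 1 to compound 2 (0.24 log units; that floor lies within the scatter); its floor lies within the scatter, so it shows no movement that can be trusted. The shown data therefore give no ground to expect a step beyond the scatter for a second exchange at that place. The expected step is an at least 1.3-fold lower number from compound 1 to compound 4 (0.12 log units; that floor lies within the scatter), that is, none beyond the scatter. Compound 4 is expected at 150000 nM, with a range from 50000 nM to 300000 nM, and a limit rather than a number is a real possibility.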

Compound 4, half-maximal cytotoxic concentration: > 200000 nM
Compound 4 gave a limit, no number; the forecaster's own chance of this, stated with the estimate: 50%; middle value at least 1.3-fold (0.12 log units) from the limit.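

In this assay, compound 4 and compound 1 share the same limit of the assay, so a five-membered aromatic ring such as 1,3-oxazol-2-yl on this saturated ring carbon gives no number that could be set against cyano. The step between these two compounds cannot be read, because both values are limits: the limit of > 200000 nM in this assay, at which 2 of the 4 values shown sit.

For the compounds shown here, the only readable comparison for the new compound is an at least 1.7-fold higher number from compound 2 to compound 4 (0.24 log units; that floor lies within the scatter); it gives a floor only, so it shows no trusted movement between 4-(1,3-oxazol-2-yl)-2-oxopyrrolidin-1-yl and 4,4-dimethyl-2-oxopyrrolidin-1-yl, and the true size of the step remains unknown.

As far as these compounds go, it remains open whether an amine or a carboxylic acid on this saturated ring carbon would give a measured number in this assay rather than a limit. Compound 3 differs from compound 4 in more than one place, so it cannot show whether the same holds with a phenyl group at this carbon on the core of compound 4.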